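The compounds below may be only part of what the source reports. "The series", "measured", "known", "first", "only" and "open" are said of these compounds alone.

Working notes on the series, all values from a functional assay on Bel-7402 cells (Homo sapiens) for inhibition, read by MTT assay, with a stated time of 24 h, tested at 1 ug/mL; on this read-out higher numbers stand for more inhibition of growth at the one concentration tested and lower numbers for less inhibition of growth

compound 1 (`O=C(O)CCCCC(CCSC(=O)c1ccccc1)SC(=O)c1ccccc1`) gives "not active" (no number reported)
compound 2 (`O=C(CCCCC(S)CCS)NO`) gives 9.12%
compound 3 (`O=C(CCCCC1CCSS1)Nc1ccc(Cl)cn1`) gives 7.44%

Compound 2 stands level with compound 3, as their two numbers lie within the scatter of each other, and compound 1 offers no number for comparison. The next compound is compound 4 (`O=C(CCCCC(S)CCS)Nc1ccccc1`), which differs from compound 2 as follows: phenyl in place of hydroxy on an amide-type nitrogen.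

Within the data shown here, no measured pair isolates this change, so the data show neither its size nor its direction. Among the measured compounds shown here, the expectation is no step beyond the scatter, resting on compound 2 at 9.12% and compound 3 at 7.44% as the only numbers so far in this assay for this series. The estimated step of a number 0.1 percentage points lower from compound 2 to compound 4 (within the scatter) is expected to stay within the scatter. For compound 4 the expected inhibition is 9% with an estimated range from 1% to 20% and a report without a number remains possible.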

Compound 4, percent growth inhibition at one concentration: 1.32%
The estimate for compound 4 lay 7.7 percentage points above the measured number, and the stated range covers the measured number.
By their numbers in this assay, from the lowest: compounds 4, 3 and 2 (each within the scatter of the next).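

In this assay the pair at this position reads a number 7.8 percentage points lower from compound 2 to compound 4 (within the scatter), for phenyl in place of hydroxy on an amide-type nitrogen. Thus, on this nitrogen, 6 heavy atoms and a six-membered aromatic ring of carbon only stand in place of 1 heavy atom without a step beyond the scatter, a reading that no earlier pair could give. No measurement shown bears on the reason for this result.

Going by these compounds, whether a benzyl or a methyl group on the same nitrogen would give a step beyond the scatter remains open. Also open, on these data alone, is how this pair would read at any concentration other than the single one tested.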